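Pyridin-3-yl to pyridin-2-yl: expected solubility of compound 3

The source may hold more compounds than are shown below. What is called first, only, known or untested is meant among the compounds shown, and "the series" means these compounds.

Measured so far in a physicochemical assay for solubility, at pH 7.4 (on this read-out lower numbers stand for lower solubility and higher numbers for higher solubility), are two compounds:
- compound 1 `Cn1cc(C(=O)Nc2ccc(-c3cccnc3)c(C(F)(F)F)c2)c(=O)c2ccccc21` gives 23 ug/mL here
- compound 2 `Cn1cc(C(=O)Nc2ccc(-c3ccccn3)c(C(F)(F)F)c2)c(=O)c2cnccc21` gives 120 ug/mL here

Compound 1 stands lowest of these two numbers, and compound 2 lies above it by more than the scatter. Next to be read is compound 3 `Cn1cc(C(=O)Nc2ccc(-c3ccccn3)c(C(F)(F)F)c2)c(=O)c2ccccc21`, which has the same atoms as compound 1, joined differently. The change is pyridin-2-yl in place of pyridin-3-yl on an aromatic carbon on an aromatic carbon of a six-membered aromatic ring of carbon only, ortho to a trifluoromethyl group and para to a large group. Within the data shown here, no measured pair shows this change alone, and the data give no firm direction. No step beyond the scatter is expected in this assay here. The expected size is a 1.1-fold higher number from compound 1 to compound 3 (0.04 log units; within the scatter) and no more than that. Compound 3 is estimated in this assay at 25 ug/mL (range 10 ug/mL to 60 ug/mL).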

Compound 3, solubility: 12 ug/mL
The estimate for compound 3 lay 2.1-fold (0.32 log units) above the measured number, within the range that was stated.
By their numbers in this assay, from the lowest: compounds 3 and 1 (each within the scatter of the next); then compound 2.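

In this assay, among these compounds, pyridin-2-yl in place of pyridin-3-yl at this position, ortho to a trifluoromethyl group and para to a large group, gives a 1.9-fold lower number from compound 1 to compound 3 (0.28 log units; within the scatter) as the first reading of this change alone. Compound 3 carries the pyridin-2-yl of compound 2 on the core of compound 1, yet compound 3 at 12 ug/mL stays within the scatter of compound 1, while compound 2 at 120 ug/mL has a different core. No measurement at hand gives a reason for this step.

From the compounds shown here alone, the size of the same change on the core of compound 2 remains open. Also open, going by these compounds, is what pyridin-4-yl, a morpholine or a carboxylic acid at this position would give in this assay on either core.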